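Piperidine carboxamides against TRPV1: an isopropyl in place of bromine

A few compounds are considered here, and "the series" means these few. Any claim that something is new, unique, unknown or untested is made for them only; others in the source may bear on it.

Measured so far:
compound 1 `O=C1COc2ccc(NC(=O)C3CCN(c4cccc(Br)c4)CC3)cc2N1`: 330 nM
compound 2 `CC(=O)N1CCc2cc(NC(=O)C3CCN(c4cccc(C(F)(F)F)c4)CC3)ccc21`: > 9000 nM
compound 3 `O=C(Nc1ccc2cc[nH]c2c1)C1CCN(c2cccc(C(F)(F)F)c2)CC1`: > 9000 nM

The study concerns a functional assay for antagonist activity at transient receptor potential cation channel subfamily V member 1 (Homo sapiens), read by FLIPR and calcium flux; a lower number here means a stronger inhibitor, a higher number a weaker inhibitor. Among the compounds with values here, compound 1 gives 330 nM in this assay and is the only compound among the three with a measured number. Compound 2 reaches only the limit of this assay at > 9000 nM. Compound 3 likewise stops at the limit of this assay, > 9000 nM. Within the data shown here, two of the three values therefore sit at the limit of > 9000 nM in this assay, at which 2 of the 3 values shown sit, and compound 1 stands alone as the one with a number; with no step between measured compounds that differ in a single place, nothing in the data ties a particular group to a particular change in potency.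

Compound 4 `CC(C)c1ccccc1N1CCC(C(=O)Nc2ccc3c(c2)NC(=O)CO3)CC1` is not yet measured. It differs from compound 1 by 2-isopropylphenyl in place of 3-bromophenyl on an amine nitrogen in a ring. Among the measured compounds shown here, since the set holds no measured step, the expectation can rest only on compound 1 and its value of 330 nM. The writer expects a step of a 2.1-fold higher number from compound 1 to compound 4 (0.33 log units; beyond the scatter), that is, a weakening that may or may not exceed the usual scatter. Compound 4 is accordingly estimated at 700 nM, within a range from 150 nM to 4000 nM.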

Compound 4, half-maximal inhibitory concentration: 180 nM
Beside the measured number, compound 4's estimate is 3.9-fold (0.59 log units) above it; the measured number falls inside the stated range.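

In this assay, putting 2-isopropylphenyl in place of 3-bromophenyl on an amine nitrogen in a ring gives a 1.8-fold lower number from compound 1 to compound 4 (0.26 log units; within the scatter), so the two compounds cannot be told apart on this read-out. Within the data shown here, this is the first step in the set between compounds that differ in one place, and it shows that this position accepts a group of nine carbon atoms, with no bromine, while compound 4 keeps a measured value of 180 nM on the core of compound 1. Nothing measured here offers a reason why the exchange leaves the value within the scatter.

The compounds shown leave open whether the identity of the group or its numbered place on the phenyl ring matters more, a question that 3-isopropylphenyl or 2-bromophenyl would address directly. It also remains open how this assay would read with a carboxylic acid or an amine on that phenyl ring, since both groups shown here, like the ring that carries them, hold no hydrogen-bond donors or acceptors.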